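The source may report more compounds than this note shows. Statements on the series, on what has been measured and on what is new or still open speak of the compounds shown alone.

Working notes on the series, which keeps one core and varies only the group on the six-membered aromatic ring of carbon. Compound 1 `Fc1ccc(NC(=S)OCCc2ccccn2)cc1` carries fluoro there; in an ADME assay on MT4 cells (Homo sapiens) for cytotoxicity, read by MTT assay (on this read-out lower numbers stand for higher toxicity in this test and higher numbers for lower toxicity in this test), compound 1 gives only a limit, > 100000 nM. Compound 2 `S=C(Nc1ccc(Cl)cc1)OCCc1ccccn1` carries chloro, and in this assay compound 2 gives 52000 nM. Compound 3 `O=[N+]([O-])c1ccc(NC(=S)OCCc2ccccn2)cc1` carries nitro; in this assay compound 3 likewise gives only a limit, > 100000 nM. Compound 3 thus stands at the limit of > 100000 nM in this assay, at which 2 of the 3 values shown sit, and of the three values shown only compound 2 sits on a number. The measured steps read an at least 1.9-fold lower number from compound 1 to compound 2 (0.28 log units; that floor lies within the scatter), a step that the two limits leave unreadable from compound 1 to compound 3 and an at least 1.9-fold higher number from compound 2 to compound 3 (0.28 log units; that floor lies within the scatter).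

Compound 4 `COc1ccc(NC(=S)OCCc2ccccn2)cc1` differs from compound 3 by methoxy in place of nitro on an aromatic carbon. Within the data shown here, the steps that bear on this change are the two ending at compound 3, a step that the two limits leave unreadable from compound 1 to compound 3 and an at least 1.9-fold higher number from compound 2 to compound 3 (0.28 log units; that floor lies within the scatter), and neither yields a readable size, as compound 3 sits at a limit. None of the steps shown gives the ring substituent a readable effect beyond the scatter. Compound 4 is therefore expected to remain in the same region, with a step of a number no higher from compound 3 to compound 4 (the limit leaves the size open) of no readable size. The estimate for compound 4 in this assay is 100000 nM, with a range from 40000 nM to 300000 nM.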

Compound 4, half-maximal cytotoxic concentration: 48000 nM
Compound 4: the middle estimate sits 2.1-fold (0.32 log units) above what was measured; the range from low to high includes it.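

In this assay, methoxy gives this position its first step that clears the scatter: an at least 2.0-fold lower number from compound 3 to compound 4 (0.31 log units; beyond the scatter), and likewise an at least 2.0-fold lower number from compound 1 to compound 4 (0.31 log units; beyond the scatter). Set against chloro, the same group shows no readable change, with a 1.1-fold lower number from compound 2 to compound 4 (0.03 log units; within the scatter), so the two substituents that give numbers cannot be told apart in this test, and neither can be ranked over the other. The ring substituent therefore does register at this place on the six-membered aromatic ring of carbon, with chloro and methoxy together on one side and fluoro and nitro on the other, but the steps from compound 1 and compound 3 are floors and not full sizes, as both of those compounds stand only at a limit: the limit of > 100000 nM in this assay, at which 2 of the 4 values shown sit.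

From the compounds shown here alone, how far compound 1 and compound 3 truly lie from compound 2 and compound 4 stays open, so neither the full size of these steps nor any order between fluoro and nitro can be stated. Also open, going by these compounds, is where an amine or a carboxylic acid at this same place would fall, and whether any group there gives a number clearly lower than those of compound 2 and compound 4.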